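This account rests on a few compounds, and the source may have more. Where it says the series, first, only, none or still open, it means among the compounds named here.

Measured compounds:
compound 1 `C=C(Br)C(=O)Nc1cccc(/C=C/C(=O)Nc2ccc(Cl)cc2)c1`: 7900 nM
compound 2 `C=C(Br)C(=O)Nc1cccc(/C=C/C(=O)Nc2ccc(OC)cc2)c1`: 2300 nM

For the measured compounds named here, in a functional assay on HT-29 cells (Homo sapiens) for inhibition, read by MTT assay, with a stated time of 72 h (on this read-out lower numbers stand for stronger inhibition and higher numbers for weaker inhibition), compound 2 gives 2300 nM, the lowest of the two numbers so far; its nearest neighbour, compound 1, gives 7900 nM. Going by the values given here, the single measured step, a 3.4-fold lower number from compound 1 to compound 2 (0.54 log units; beyond the scatter), is modest but beyond the scatter.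

Compound 3 `C=C(Br)C(=O)Nc1cccc(/C=C/C(=O)Nc2ccc(SC(F)(F)F)cc2)c1` is not yet measured in this assay. It differs from compound 2 in one place: (trifluoromethyl)sulfanyl in place of methoxy on an aromatic carbon. Among the compounds with values here, no measured pair covers a (trifluoromethyl)sulfanyl group on that aromatic carbon, so the only step that bears on this change, a 3.4-fold lower number from compound 1 to compound 2 (0.54 log units; beyond the scatter), does so indirectly, by showing that exchanging the group at this position can move the number by a modest amount. Since the change now leaves the methoxy that went with the lower number, the step of a 2.0-fold higher number from compound 2 to compound 3 (0.29 log units; within the scatter) is expected to run toward a somewhat higher number, though a value within the scatter of compound 2 would not surprise. The number for compound 3 in this assay is therefore estimated at 4500 nM, with a range from 1500 nM to 14000 nM.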

Compound 3, half-maximal inhibitory concentration: 39800 nM
For compound 3 the middle estimate is 8.8-fold (0.95 log units) below the measured one; measured number outside the range, above it.
By their numbers in this assay, from the lowest: compound 2; then compound 1; then compound 3.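

In this assay, for the compounds shown here, the (trifluoromethyl)sulfanyl group gives the highest number of the three, and the step of a 17-fold higher number from compound 2 to compound 3 (1.24 log units; beyond the scatter) is rated large, whereas the only earlier step at this position was modest. The new compound also compares unfavourably with the chloro compound, with a 5.0-fold higher number from compound 1 to compound 3 (0.70 log units; beyond the scatter) as a modest step beyond the scatter, so the order from the lowest number runs methoxy, chloro, (trifluoromethyl)sulfanyl. Exchanging the group on this aromatic carbon, para to a large group, can therefore move the number much further than the first pair showed, and both exchanges away from methoxy on this carbon go toward weaker inhibition, though nothing available explains the size of these steps.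

With only three groups at this place, the compounds shown leave open whether the order would hold for others, such as a hydroxyl, an amine, a carboxylic acid or a longer alkoxy chain. They also leave open whether the large step seen here would recur if the same exchange were made with another part of the shared core changed.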